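A Second Chloro Enters the Phenoxy Ring of Compound 2

A few compounds are considered here, and "the series" means these few. Any claim that something is new, unique, unknown or untested is made for them only; others in the source may bear on it.

The three measured compounds share a core carrying two nitro groups and a trifluoromethyl group, with an oxime ether ending in a fluorobenzyl group. Compound 1 `O=[N+]([O-])c1cc(C(F)(F)F)cc([N+](=O)[O-])c1Oc1ccccc1/C=N\OCc1ccccc1F` is the unsubstituted parent; in a functional assay on A549 cells (Homo sapiens) for antiproliferative activity, read by MTT assay, with a stated time of 48 h (on this read-out lower numbers stand for stronger inhibition and higher numbers for weaker inhibition), compound 1 gives 860 nM. Compound 2 `O=[N+]([O-])c1cc(C(F)(F)F)cc([N+](=O)[O-])c1Oc1ccc(Cl)cc1/C=N\OCc1ccccc1F` carries a chloro on the phenoxy ring, and in this assay compound 2 gives 2570 nM. Compound 3 `O=[N+]([O-])c1cc(C(F)(F)F)cc([N+](=O)[O-])c1Oc1ccc(Br)cc1/C=N\OCc1ccccc1F` carries a bromo instead, and in this assay compound 3 gives 1280 nM.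

Among these three numbers compound 2 stands highest; its step from compound 1 was a 3.0-fold higher number from compound 1 to compound 2 (0.48 log units; beyond the scatter), while compound 3 sits a 2.0-fold lower number from compound 2 to compound 3 (0.30 log units; within the scatter) away, within the scatter.

Compound 4 `O=[N+]([O-])c1cc(C(F)(F)F)cc([N+](=O)[O-])c1Oc1c(Cl)cc(Cl)cc1/C=N\OCc1ccccc1F` differs from compound 2 by chloro in place of hydrogen on an aromatic carbon, placed on an aromatic carbon of a six-membered aromatic ring of carbon only, ortho to a large group and meta to a chloro group. Among the compounds with values here, the only step that bears on it is chloro in place of hydrogen, seen in a 3.0-fold higher number from compound 1 to compound 2 (0.48 log units; beyond the scatter); the bromo step a 1.5-fold higher number from compound 1 to compound 3 (0.17 log units; within the scatter) stayed within the scatter. A second chloro is therefore expected to raise the number again, modestly, as a 1.6-fold higher number from compound 2 to compound 4 (0.19 log units; within the scatter) in this assay. Compound 4 is estimated at 4000 nM, with a range from 1500 nM to 10000 nM.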

Compound 4, half-maximal inhibitory concentration: 1230 nM
Compound 4: the middle estimate sits 3.3-fold (0.51 log units) above what was measured; measured number outside the range, below it.
By their numbers in this assay, from the lowest: compounds 1, 4, 3 and 2 (each within the scatter of the next, the first and the last beyond it).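

Chloro in place of hydrogen does not carry one fixed direction in this series: in this assay, the first such swap gave a 3.0-fold higher number from compound 1 to compound 2 (0.48 log units; beyond the scatter) and the swap at this new place gave a 2.1-fold lower number from compound 2 to compound 4 (0.32 log units; beyond the scatter), two opposite moves, each beyond the scatter. Within the data shown here, the new chloro stands ortho to a large group and meta to a chloro group, so a chloro's effect here cannot be read from a single swap on the phenoxy ring, as the earlier compounds alone might have suggested. Nothing measured here explains why the direction reverses.

The compounds shown leave open whether the change in direction belongs to this place itself or depends on the chloro already on the ring, since a chloro at this place on a ring without that first chloro is not among them. They also leave open how a bromo, a methyl group, a methoxy group or an amine at this same place would move the number.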